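A few compounds are considered here, and "the series" means these few. Any claim that something is new, unique, unknown or untested is made for them only; others in the source may bear on it.

In a functional assay on HL-60 cells (Homo sapiens) for cytotoxicity, read by luminescence and CellTiter-Glo, with a stated time of 3 days; a higher number here means a weaker inhibitor, a lower number a stronger inhibitor:

- compound 1 `N#Cc1ccc(NC(=O)c2ccc3cccnc3c2O)c(F)c1`: 730 nM
- compound 2 `O=C(Nc1ccc(Cl)cc1Cl)c1ccc2cccnc2c1O`: 610 nM
- compound 3 `N#Cc1ccc(NC(=O)c2ccc3cccnc3c2O)cc1`: 370 nM

Compound 3 gives 370 nM, and neither compound 1 nor compound 2 lies beyond the usual scatter from it. The next compound to consider is compound 4 `O=C(Nc1ccc(Cl)cc1)c1ccc2cccnc2c1O`, which has chloro in place of cyano on an aromatic carbon.

Among the measured compounds shown here, no measured step makes this exact swap. For the measured compounds named here, the only measured step, a 2.0-fold lower number from compound 1 to compound 3 (0.30 log units; within the scatter), puts hydrogen in place of fluoro and leaves the cyano untouched, so it bears on the swap only indirectly. It does show that one change on this ring stayed within the scatter. Compound 2 already carries chloro and gives 610 nM, so chloro on this ring is compatible with a value in the same range. A large step in this assay therefore seems unlikely.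

The expected change is a 1.2-fold higher number from compound 3 to compound 4 (0.09 log units; within the scatter), which is not expected to exceed the scatter. For compound 4 the estimated value is 450 nM, with an expected range from 180 nM to 1000 nM.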

Compound 4, half-maximal inhibitory concentration: 630 nM
Beside the measured number, compound 4's estimate is 1.4-fold (0.15 log units) below it; low and high end bracket the measured number.
By their numbers in this assay, from the lowest: compounds 3, 2, 4 and 1 (each within the scatter of the next).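

In this assay, putting chloro in place of cyano, on an aromatic carbon para to a large group, gives a 1.7-fold higher number from compound 3 to compound 4 (0.23 log units; within the scatter), so this direct swap at this position stays within the scatter. Hydrogen in place of a chloro gives a 1.0-fold higher number from compound 2 to compound 4 (0.01 log units; within the scatter), which shows that this change on the same ring also stays within the scatter. No measurement here offers an explanation for either step.

Going by these compounds, all four compounds carry only small groups on this ring, so it remains open whether an amine, a carboxylic acid or a longer chain para to the large group would move the number beyond the scatter. On these data alone, the shared core is the same throughout, so what a change there would do also remains open.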